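Removing a Methyl Group from a Fused-Ring Amide

This account rests on a few compounds, and the source may have more. Where it says the series, first, only, none or still open, it means among the compounds named here.

Of the compounds shown here, two built on one shared core have been tested in a functional assay on the whole organism with Mus musculus as the target; a lower number here means that less compound is needed, a higher number that more compound is needed for the effect. In this assay compound 1 `NC(=O)/C=C1\CCc2cc(F)c(F)cc21` gives 64 mg/kg. Compound 2 `Cc1cccc2c1/C(=C/C(N)=O)CC2` gives 82 mg/kg in this assay. Going by the values given here, compound 2 has the higher of the two numbers, but its only neighbour, compound 1, sits so close that the gap lies within the scatter of repeated measurements, so the two cannot be ranked. Compound 3 `NC(=O)/C=C1\CCc2ccccc21` has not yet been measured in this assay. The change from compound 2 to compound 3 is hydrogen in place of methyl on an aromatic carbon. Among the compounds with values here, no step between two measured compounds has been recorded, so nothing seen so far shows what this change does. The step of a 1.1-fold lower number from compound 2 to compound 3 (0.06 log units; within the scatter) is expected to be small, with no direction beyond the scatter. Compound 3 is estimated at 72 mg/kg, with a range from 36 mg/kg to 145 mg/kg.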

Compound 3, dose for half-maximal effect: 108 mg/kg
Compound 3: middle estimate off by 1.5-fold (0.18 log units), on the low side; the measured number falls inside the stated range.
By their numbers in this assay, from the lowest: compounds 1, 2 and 3 (each within the scatter of the next).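

Going by these compounds alone, replacing the methyl group on this aromatic carbon with hydrogen gives the first direct reading of this position in this assay (a 1.3-fold higher number from compound 2 to compound 3 (0.12 log units; within the scatter)). In this single pair, a compound with methyl at this position and one with hydrogen there cannot be told apart, so the methyl group shows no measurable contribution to the dose needed. No accompanying measurement bears on this result.

From the compounds shown here alone, whether a different group on this aromatic carbon, such as an ethyl chain, a methoxy group or an amine, would produce a step beyond the scatter remains open. One pair also cannot show how a chlorine atom or a carboxylic acid would read here, or whether the methyl-to-hydrogen change would look the same elsewhere on the shared core.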